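Amide ring swap on the shared core: compound 3

The source may hold more compounds than are shown below. What is called first, only, known or untested is meant among the compounds shown, and "the series" means these compounds.

Within the data shown here, compound 2 `Cc1nc(S(C)(=O)=O)ccc1Oc1ncnc(OC2CCN(C(=O)c3nc(C(C)(C)F)no3)CC2)c1F` holds the higher of the two numbers measured so far in a functional assay on isolated protein for inhibition of Glucose-dependent insulinotropic receptor (Homo sapiens), read by HTRF and cAMP accumulation (on this read-out higher numbers stand for an effect only at larger amounts of compound and lower numbers for an effect already at smaller amounts), giving 43.4 nM. Compound 1 `Cc1nc(S(C)(=O)=O)ccc1Oc1ncnc(OC2CCN(C(=O)SC(C)C)CC2)c1F` gives 6.8 nM in this assay; the step of a 6.4-fold higher number from compound 1 to compound 2 (0.80 log units; beyond the scatter) replaced a non-ring acyl substituent with a five-membered aromatic ring on the carbonyl carbon. Compound 3 `CCc1cnc(C(=O)N2CCC(Oc3ncnc(Oc4ccc(S(C)(=O)=O)nc4C)c3F)CC2)nc1` is the next member of the series: a group of 8 heavy atoms (6 carbon, 2 nitrogen; one six-membered aromatic ring with 2 hetero atoms) in place of a group of 9 heavy atoms (5 carbon, 2 nitrogen, 1 oxygen, 1 fluorine; one five-membered aromatic ring with 3 hetero atoms), on a carbonyl carbon. Among the measured compounds shown here, no measured step compares two aromatic substituents on this carbonyl carbon; the only step known, a 6.4-fold higher number from compound 1 to compound 2 (0.80 log units; beyond the scatter), concerns a ring entering where none stood, so it bears only loosely on the present change. On that footing the expectation is a step of a 1.4-fold lower number from compound 2 to compound 3 (0.16 log units; within the scatter), with direction uncertain and a fair chance of nothing beyond the scatter. Compound 3 is therefore estimated at 30 nM in this assay, with a range from 8 nM to 120 nM.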

Compound 3, half-maximal effective concentration: 4.7 nM
For compound 3 the middle estimate is 6.4-fold (0.81 log units) above the measured one; the measured number lies below the stated range.
By their numbers in this assay, from the lowest: compounds 3 and 1 (each within the scatter of the next); then compound 2.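

On the carbonyl carbon of the shared core, one aromatic ring in place of another is far from neutral in this assay: 5-ethylpyrimidin-2-yl gives a 9.2-fold lower number from compound 2 to compound 3 (0.97 log units; beyond the scatter) and so the rise seen in a 6.4-fold higher number from compound 1 to compound 2 (0.80 log units; beyond the scatter) does not hold for every aromatic ring at this place. Against isopropylsulfanyl the pyrimidine gives a 1.4-fold lower number from compound 1 to compound 3 (0.16 log units; within the scatter), so a six-membered aromatic ring and a non-ring group can stand here with no difference beyond the scatter. Nothing available explains why the two rings differ.

The compounds shown do not separate the share of the ethyl group from that of the pyrimidine ring in this step. As far as these compounds go, whether a plain phenyl ring or an amine on this carbonyl carbon would match compound 3 also stays open.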